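Moving the Methoxycarbonyl Group on an E-selectin Binder

A few compounds are considered here, and "the series" means these few. Any claim that something is new, unique, unknown or untested is made for them only; others in the source may bear on it.

This account concerns three related compounds examined for binding to E-selectin. Compound 1 `CCCCCCCCCCOc1cc(OCCCCCCCCCC)cc(OCCCCCCN(Cc2ccc(C(=O)O)cc2)c2ccc(C(=O)O)cc2)c1` carries two free carboxylic acids, but in an assay on isolated protein for binding affinity to E-selectin (Homo sapiens), read by ELISA, tested at 100 uM (on this read-out lower numbers stand for less inhibition and higher numbers for more inhibition at the one concentration tested (going by the name of the read-out)), compound 1 gives "not determined" (no result reported), so no number is available for it. Going by the values given here, compound 2 `CCCCCCCCCCOc1cccc(OCCCCCC(=O)N(Cc2ccc(C(=O)OC)cc2)c2cccc(C(=O)OC)c2)c1` is the only compound with a number: in this assay compound 2 gives 18%, a modest degree of inhibition at the single concentration tested. Compound 3 `CCCCCCCCCCOc1cccc(OCCCCCC(=O)N(Cc2ccc(C(=O)OC)cc2)c2ccc(C(=O)OC)cc2)c1` has not yet been measured. It shares every atom with compound 2, joined differently: 4-(methoxycarbonyl)phenyl in place of 3-(methoxycarbonyl)phenyl on an amide-type nitrogen. Among the compounds with values here, no pair of measured compounds differing in a single place is available, so there is no comparison to show how such a change moves the read-out in this assay. With nothing to suggest otherwise, the step from compound 2 to compound 3 is expected to stay within the usual scatter, that is a number 2 percentage points higher from compound 2 to compound 3 (within the scatter). On that basis compound 3 is estimated to give 20% in this assay, with a plausible range from 5% to 40%, and the reported measurement will show whether this expectation holds.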

Compound 3, a percentage reported as inhibition, at one concentration (the size of the read-out at that concentration, not a potency): 65%
Beside the measured number, compound 3's estimate is 45 percentage points below it, and the stated range ends below it.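

The step shows that in this assay the read-out is highly sensitive to where the methoxycarbonyl group sits on the phenyl ring carried by the amide-type nitrogen: 4-(methoxycarbonyl)phenyl in place of 3-(methoxycarbonyl)phenyl gives a number 47 percentage points higher from compound 2 to compound 3 (beyond the scatter). The two compounds hold the same atoms and differ only in how they are joined, so this pair shows that a change of arrangement alone, with composition and the counted hydrogen-bond donors and acceptors untouched, can be enough to shift the result well beyond the scatter. No measurement is available that would explain why this arrangement gives the greater inhibition.

The compounds shown leave open whether a carboxylic acid in place of the methyl ester of the 4-(methoxycarbonyl)phenyl group would keep this level of inhibition, and whether an amine at that place, or a longer chain on the shared core, would raise or lower it. Going by these compounds alone, they also leave open whether the same shift would appear on other cores, as this single pair is the only comparison available at the one concentration tested.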